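This account rests on a few compounds, and the source may have more. Where it says the series, first, only, none or still open, it means among the compounds named here.

Of the compounds shown here, two have been measured in a toxicity assay on the whole organism (H4IIE cells) for cytotoxicity, with Rattus norvegicus as the target, read by MTT assay, with a stated time of 24 h, tested at 0.07 uM; on this read-out lower numbers stand for a stronger effect and higher numbers for a weaker effect at the one concentration tested. Compound 1 `Cc1ccc(C(C)C)c(OC(=O)Nc2ccc([N+](=O)[O-])cc2)c1` gives 97.8%, and compound 2 `Cc1ccc(C(C)C)cc1OC(=O)NC1CCCC1` gives 94.4%. Compound 2 holds the lower of the two numbers, but its gap to compound 1 lies within the scatter, so the two read alike. Compound 3 `Cc1ccc(C(C)C)cc1OC(=O)Nc1cccc(F)c1` is not yet measured and differs from compound 2 by 3-fluorophenyl in place of cyclopentyl on an amide-type nitrogen. Compound 1, which also carries an aromatic ring on that nitrogen, gives 97.8%. For compound 3 the expected step is therefore a number 1.6 percentage points higher from compound 2 to compound 3 (within the scatter), none beyond the scatter. Compound 3 is expected to give 96%, between 88% and 104%.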

Compound 3, a percentage reported as activity, at one concentration (the size of the read-out at that concentration, not a potency): 98.1%
Compound 3: middle estimate off by 2.1 percentage points, on the low side, and the stated range covers the measured number.
By their numbers in this assay, from the lowest: compounds 2, 1 and 3 (each within the scatter of the next).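

For the compounds shown here, compound 2 and compound 3 form the first pair that differs in one place, on an amide-type nitrogen whose other neighbour is the carbonyl carbon. In this assay the swap of cyclopentyl for 3-fluorophenyl gives a number 3.7 percentage points higher from compound 2 to compound 3 (within the scatter) so the two read alike at the one concentration tested. No supporting data here bear on this result.

On these data alone, whether an amine, a carboxylic acid or a longer chain on that nitrogen would read differently stays open. So does the read-out of these compounds at higher concentrations.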